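This account rests on a few compounds, and the source may have more. Where it says the series, first, only, none or still open, it means among the compounds named here.

Working notes on a short series tested in an assay on isolated protein for inhibition of sodium channel protein type 4 subunit alpha (Homo sapiens); a higher number here means that more compound is needed for the effect, a lower number that less compound is needed. Compound 1, `Cc1cccc(C)c1NC(=O)[C@H]1CCCN1Cc1ccccc1`, gives 31600 nM. Compound 2, `Cc1cccc(C)c1N1CN2CCC[C@@H]2C1=O`, gives 501000 nM. Compound 3, `Cc1cccc(C)c1OC[C@H](N)c1ccccc1`, gives 3020 nM, the lowest of the three numbers; compound 1 stands well above it, beyond the scatter, and compound 2 stands further above still, also beyond the scatter. Each of these three compounds differs from the others in more than one place, so no single-change step can be read from them.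

Compound 4, `Cc1cccc(C)c1OC[C@@H](N)c1ccccc1`, is the next compound to be measured in this assay. Its relation to compound 3 is as follows: the two compounds have the same atoms and bonds and differ only in configuration as drawn: 1 of 1 stereo elements differ; a stereocentre at a saturated chain carbon is drawn R in compound 3 and S in compound 4. Going by the values given here, no measured pair differs only in configuration, so the size of such a step is unknown here. For this kind of change a modest shift is expected, most likely towards a higher number, and it may not exceed the scatter. The estimate this implies is a step of a 1.7-fold higher number from compound 3 to compound 4 (0.22 log units; within the scatter). For compound 4 the expected value in this assay is 5000 nM, with a range from 1500 nM to 20000 nM.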

Compound 4, half-maximal effective concentration: 3020 nM
Compound 4: the middle estimate sits 1.7-fold (0.22 log units) above what was measured; the range from low to high includes it.
By their numbers in this assay, from the lowest: compounds 3 and 4 (each within the scatter of the next); then compound 1; then compound 2.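

Going by these compounds alone, this is the first pair that isolates configuration, so the comparison is a clean one: the fact that compounds 3 and 4 differ only in the configuration as drawn. In this assay the stereocentre at the saturated chain carbon gives no change at the digits printed from compound 3 to compound 4 (within the scatter), so this read-out does not separate the form drawn R from the form drawn S at this position. The finding rests on this single pair and does not extend to the stereocentres of compound 1 or compound 2.

Going by these compounds, it remains open whether configuration at this carbon would stay as silent with a carboxylic acid in place of the amine, or with a longer chain between the ether oxygen and the stereocentre. The compounds shown also do not tell how much the number depends on the amine or on the phenyl group at this carbon.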